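A few compounds are considered here, and "the series" means these few. Any claim that something is new, unique, unknown or untested is made for them only; others in the source may bear on it.

Working notes on the series. Compound 3 `CCc1ccccc1OC1CCN(c2ccc(-n3ccnc3)nn2)CC1` gives 4 nM in an assay on microsomes from liver for inhibition of acyl-CoA desaturase 1 (Rattus norvegicus); a higher number here means a weaker inhibitor, a lower number a stronger inhibitor. Compound 1 `Cc1nnc(-c2ccc(N3CCC(Oc4ccccc4C(F)(F)F)CC3)nn2)s1` gives 2.3 nM and compound 2 `Oc1nnc(-c2ccc(N3CCC(Oc4ccccc4C(F)(F)F)CC3)nn2)s1` gives 6.1 nM; compound 3 sits within the scatter of both of them. Compound 4 `Cc1ccc(OC2CCN(c3ccc(-n4ccnc4)nn3)CC2)cc1` differs from compound 3 by 4-methylphenyl in place of 2-ethylphenyl on an oxygen on a saturated carbon. Among the measured compounds shown here, the only measured step, a 2.7-fold higher number from compound 1 to compound 2 (0.42 log units; beyond the scatter), concerns hydroxy in place of methyl on an aromatic carbon on a different part of the molecule and does not bear on this change. For the measured compounds named here, no measured pair informs the aryl ether, so the expectation rests on the absence of a precedent: a small loss in this assay is expected, as a 3.0-fold higher number from compound 3 to compound 4 (0.48 log units; beyond the scatter). For compound 4 the estimate is 12 nM, with a range of 3 nM to 50 nM.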

Compound 4, half-maximal inhibitory concentration: 527 nM
Beside the measured number, compound 4's estimate is 44-fold (1.64 log units) below it; the whole stated range lies below it.
By their numbers in this assay, from the lowest: compounds 1, 3 and 2 (each within the scatter of the next, the first and the last beyond it); then compound 4.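

In this assay, 4-methylphenyl in place of 2-ethylphenyl on an oxygen on a saturated carbon gives a 130-fold higher number from compound 3 to compound 4 (2.12 log units; beyond the scatter), so this position responds strongly to the substitution of the aryl group. The change is large even though both groups are carbon-only aromatic rings, with no hydrogen-bond donor or acceptor and no net charge on either side. Nothing available explains the size of this step. Two things change at once here, the ethyl giving way to a methyl and the substituent's place on the ring, and the compounds shown do not separate them. As far as these compounds go, how an unsubstituted phenyl on the same oxygen would read also remains open.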